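Urea-linked pyrazoles: methoxy to hydroxy on the aryl ring

The compounds below may be only part of what the source reports. "The series", "measured", "known", "first", "only" and "open" are said of these compounds alone.

Of the compounds shown here, two carry numbers so far. Compound 1 `O=C(Nc1cccc(-n2cc(-c3ccncc3)c(-c3ccc(Cl)c(O)c3)n2)c1)Nc1ccc(Cl)c(Cl)c1` gives 2890 nM in a functional assay on HCC 2998 cells (Homo sapiens) for inhibition, read by sulforhodamine B assay, with a stated time of 48 h; a higher number here means a weaker inhibitor of growth, a lower number a stronger inhibitor of growth. Compound 2 `COc1cc(-c2nn(-c3cccc(NC(=O)Nc4ccc(Cl)c(C(F)(F)F)c4)c3)cc2-c2ccncc2)ccc1Cl` gives 1550 nM in this assay; this is the smaller of the two numbers shown, yet compound 2 and compound 1 sit within the scatter of each other, so no order between them is established. For the measured compounds named here, compound 1 and compound 2 differ in two places at once, and no single step between them is available; their two values show only that both lie in the same broad region.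

Compound 3 `O=C(Nc1cccc(-n2cc(-c3ccncc3)c(-c3ccc(Cl)c(O)c3)n2)c1)Nc1ccc(Cl)c(C(F)(F)F)c1` is not yet measured. It differs from compound 2 by hydrogen in place of methyl on an oxygen on an aromatic ring. With no measured step of this kind in the series, the expectation for the step from compound 2 to compound 3 is none beyond the scatter, with a slight lean toward a higher number in this assay, given that the hydroxy-bearing compound 1 gives 2890 nM. The expected step is a 1.4-fold higher number from compound 2 to compound 3 (0.13 log units; within the scatter). Compound 3 is therefore estimated at 2100 nM, with a range from 900 nM to 4800 nM.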

Compound 3, concentration for 50% growth inhibition: 1060 nM
Estimate against measurement, compound 3: 2.0-fold (0.30 log units) above; low and high end bracket the measured number.
By their numbers in this assay, from the lowest: compounds 3, 2 and 1 (each within the scatter of the next, the first and the last beyond it).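

With the trifluoromethyl-bearing aryl urea held fixed, methoxy to hydroxy on the 4-chloro-3-methoxyphenyl ring gives in this assay (a 1.5-fold lower number from compound 2 to compound 3 (0.17 log units; within the scatter)), so a methyl on this oxygen has no resolved effect on the number in this pair. With the hydroxy group held fixed, trifluoromethyl in place of chloro on an aromatic carbon gives (a 2.7-fold lower number from compound 1 to compound 3 (0.44 log units; beyond the scatter)), a modest step and the only one here beyond the scatter, which makes this aromatic carbon, rather than the oxygen, the place where a single change has so far registered. Nothing at hand bears on why either step has the size it has.

The compounds shown leave open whether the step from chloro to trifluoromethyl carries over when methoxy replaces hydroxy, since each change is seen in one pair only. Also open, as far as these compounds go, is how the series responds to other groups at these two places, such as an ethoxy group or an amine on the aromatic ring in place of hydroxy, or a nitrile in place of trifluoromethyl.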